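Working notes on the step to compound 3

This account rests on a few compounds, and the source may have more. Where it says the series, first, only, none or still open, it means among the compounds named here.

Compound 1 `Oc1cccc2[nH]c(-c3ccc(-c4ccc(-c5ccc(F)cc5)cc4)cc3)nc12`: 6320 nM
Compound 2 `CN(C)c1ccc(-c2ccc(-c3ccc(-c4nc5c(O)cccc5[nH]4)cc3)cc2)cc1`: 4100 nM

Among the compounds with values here, in a functional assay on ZR-75-1 cells (Homo sapiens) for inhibition, read by sulforhodamine B assay (on this read-out higher numbers stand for weaker inhibition of growth and lower numbers for stronger inhibition of growth), compound 2 stands level with compound 1, the only other measured compound, and their two values lie within the scatter of each other. Compound 3 `Oc1cccc2[nH]c(-c3ccc(-c4ccc(-c5cccc(Cl)c5)cc4)cc3)nc12` has 3-chlorophenyl in place of 4-(dimethylamino)phenyl on an aromatic carbon. Within the data shown here, one measured step bears on this change, a 1.5-fold lower number from compound 1 to compound 2 (0.19 log units; within the scatter), where dimethylamino took the place of fluoro on an aromatic carbon. Among the measured compounds shown here, that step stayed within the scatter, but it is a single step, and no measured compound carries 3-chlorophenyl. Going by these compounds, no step beyond the scatter is therefore expected in this assay, and the direction remains open. The expected change is a 1.2-fold higher number from compound 2 to compound 3 (0.09 log units; within the scatter). For compound 3 the estimate is 5000 nM, with an expected range of 2200 nM to 11000 nM.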

Compound 3, concentration for 50% growth inhibition: 2410 nM
Compound 3: middle estimate off by 2.1-fold (0.32 log units), on the high side, and the stated range covers the measured number.
By their numbers in this assay, from the lowest: compounds 3, 2 and 1 (each within the scatter of the next, the first and the last beyond it).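

In this assay, this position on an aromatic carbon now shows a step beyond the scatter, though a modest one: 3-chlorophenyl in place of 4-fluorophenyl gives a 2.6-fold lower number from compound 1 to compound 3 (0.42 log units; beyond the scatter). Within the data shown here, the exchange of 4-(dimethylamino)phenyl for 3-chlorophenyl gives a 1.7-fold lower number from compound 2 to compound 3 (0.23 log units; within the scatter), so the aryl group at this place can shift the read-out, but only the pair with 4-fluorophenyl separates clearly. Nothing available explains either step.

Open, going by these compounds, is whether 4-chlorophenyl or 3-fluorophenyl would read like 3-chlorophenyl, which would separate the effect of the halogen from that of its place on the ring. Also open, on these data alone, is how a carboxylic acid or a primary amine on this ring would read in this assay, and whether any group here moves the number further than these steps.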